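Swapping methoxy groups on a compound at the limit

The source may hold more compounds than are shown below. What is called first, only, known or untested is meant among the compounds shown, and "the series" means these compounds.

Measured in a functional assay on HeLa cells (Homo sapiens) for cytotoxicity, read by MTT assay, with a stated time of 48 h; a higher number here means a weaker inhibitor, a lower number a stronger inhibitor:
- Compound 1 `COc1cc(OC)c(/C=C/C(=O)/C=C/c2cc3ccccc3nc2Oc2ccccc2)c(OC)c1` gives > 10000 nM (a limit of the assay)
- Compound 2 `COc1ccc(/C=C/C(=O)/C=C/c2cc3ccccc3nc2Oc2cccc(Cl)c2)c(OC)c1` gives > 10000 nM (a limit of the assay)
- Compound 3 `COc1ccc(/C=C/C(=O)/C=C/c2cc3ccccc3nc2Oc2cccc(Cl)c2)cc1OC` gives > 10000 nM (a limit of the assay)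

None of these three entries is a true number, so the series offers no ranking. Compound 3 stands at > 10000 nM (a limit, not a number) and so gives only a bound as a starting point. Across the series, the record so far is the limit of > 10000 nM in this assay, at which 3 of the 3 values shown sit, with no exact reading among them.

The next compound is compound 4 `COc1cc(OC)c(/C=C/C(=O)/C=C/c2cc3ccccc3nc2Oc2cccc(Cl)c2)c(OC)c1` and the change that leads to it is 2,4,6-trimethoxyphenyl in place of 3,4-dimethoxyphenyl on a double-bonded chain carbon bound to a double-bonded chain carbon on a double-bonded chain carbon bound to a double-bonded chain carbon. Going by the values given here, the only measured step at this place, a step that the two limits leave unreadable from compound 2 to compound 3, offers no size to carry over. Compound 1 also carries the 2,4,6-trimethoxyphenyl group, and compound 1 sits at > 10000 nM (again a limit) in the same test.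

With that evidence, no shift beyond the usual scatter is expected, and the expected step is a step that the limit leaves unreadable from compound 3 to compound 4 in this assay with no clear direction. Compound 4 is estimated at 15000 nM with an expected range of 7000 nM to 40000 nM. The outcome for compound 4 may well be only a limit.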

Compound 4, half-maximal inhibitory concentration: > 10000 nM
Compound 4 gave a limit, no number; the forecaster's own chance of this, stated with the estimate: 85%; the middle value does not contradict the limit.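

Going by these compounds alone, compound 4 gives only a limit in this assay, as do compound 1, compound 2 and compound 3, so no step from any of them to compound 4 can be read. The compounds shown leave open whether changing the methoxy groups or adding the chloro group alters cytotoxicity at all: the limit of > 10000 nM in this assay, at which 4 of the 4 values shown sit.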